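Pyridin-2-yl for phenyl on the benzylic arm

The source may hold more compounds than are shown below. What is called first, only, known or untested is meant among the compounds shown, and "the series" means these compounds.

Measured compounds:
compound 1 `O=C(c1cc(Cl)ccc1-c1ccncc1)N1CCC(O)(Cc2ccccc2)CC1`, 2.4 nM
compound 2 `O=C(c1ccccc1-c1ccncc1)N1CCC(O)(Cc2ccccc2)CC1`, 7.9 nM

Of the compounds shown here, two have been measured in an assay for inhibition of cholesterol 24-hydroxylase (Homo sapiens), using NADPH, with stated times of 15 min and 5 min; a higher number here means a weaker inhibitor, a lower number a stronger inhibitor. Compound 1 `O=C(c1cc(Cl)ccc1-c1ccncc1)N1CCC(O)(Cc2ccccc2)CC1` gives 2.4 nM in this assay. Going by the values given here, compound 2 `O=C(c1ccccc1-c1ccncc1)N1CCC(O)(Cc2ccccc2)CC1` gives 7.9 nM, which is the highest of the two numbers; its nearest neighbour is compound 1, and the step of a 3.3-fold higher number from compound 1 to compound 2 (0.52 log units; beyond the scatter) is the only measured step in the set.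

Compound 3 `O=C(c1ccccc1-c1ccncc1)N1CCC(O)(Cc2ccccn2)CC1` has not yet been measured. It differs from compound 2 by pyridin-2-yl in place of phenyl on a saturated chain carbon bound to a saturated ring carbon. Among the compounds with values here, the one measured step concerns a change on the aromatic ring of the shared core, not on the benzyl group, so no measured step bears directly on the present change. The data give no guide to the effect of exchanging phenyl for pyridin-2-yl at this place, and the step is therefore expected to stay within the usual scatter, with a possible modest shift toward a higher number.

For compound 3 the expected value in this assay is 12 nM, with a range of 4 nM to 35 nM. The step from compound 2 that this estimate means is expected to be a 1.5-fold higher number from compound 2 to compound 3 (0.18 log units; within the scatter).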

Compound 3, half-maximal inhibitory concentration: 21 nM
Beside the measured number, compound 3's estimate is 1.8-fold (0.24 log units) below it; measured number inside the range.
By their numbers in this assay, from the lowest: compound 1; then compound 2; then compound 3.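

The position on a saturated chain carbon bound to a saturated ring carbon is not silent in this assay since pyridin-2-yl in place of phenyl there gives a 2.7-fold higher number from compound 2 to compound 3 (0.42 log units; beyond the scatter). Going by these compounds alone, this is the first measured step at this place, and it shows that exchanging one ring carbon for nitrogen, with the hydrogen-bond acceptor count going up by one and the heavy atom count unchanged, makes the compound a modestly weaker inhibitor. The benzylic arm therefore joins the aromatic ring of the shared core, where the step from compound 1 to compound 2 was also beyond the scatter, as a place where a single change registers in this assay. No available evidence bears on why the pyridin-2-yl group gives the higher number.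

The compounds shown leave open whether pyridin-3-yl or pyridin-4-yl at the same place would behave like pyridin-2-yl or like phenyl. They also leave open whether a chloro group on the aromatic ring of the core would lower the number for the pyridin-2-yl compound as it does for the phenyl one.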